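Compound 3 and the quinolin-2-yl swap

The source may report more compounds than this note shows. Statements on the series, on what has been measured and on what is new or still open speak of the compounds shown alone.

Measured in a functional assay on SK-BR-3 cells (Homo sapiens) for antiproliferative activity, read by MTT assay, with a stated time of 72 h (a lower number here means a stronger inhibitor, a higher number a weaker inhibitor), as follows:
Compound 1 `CCN1CCN(c2cc(C)c3cc(NC(=O)c4ccc(C)cc4)ccc3n2)CC1` gives 11400 nM
Compound 2 `CCN1CCN(c2cc(C)c3cc(NC(=O)c4ccc(Br)cc4)ccc3n2)CC1` gives 6310 nM
Compound 3 `CCc1ccccc1C(=O)Nc1ccc2nc(N3CCN(CC)CC3)cc(C)c2c1` gives 23900 nM

Compound 3 has the highest number of the three in this assay at 23900 nM and is the weakest of this small set. Compound 1 and compound 2 are not separated, since the record shows a 1.8-fold lower number from compound 1 to compound 2 (0.26 log units; within the scatter) for bromo in place of methyl.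

The next compound is compound 4 `CCN1CCN(c2cc(C)c3cc(NC(=O)c4ccc5ccccc5n4)ccc3n2)CC1`, which carries quinolin-2-yl in place of 2-ethylphenyl on a carbonyl carbon. Within the data shown here, the counted difference reads quinolin-2-yl in place of 2-ethylphenyl on a carbonyl carbon and no measured compound yet holds the entering group.

Among the measured compounds shown here, two measured steps bear on this change, since both alter the group on the same carbonyl carbon. They are a 2.1-fold higher number from compound 1 to compound 3 (0.32 log units; beyond the scatter) and a 3.8-fold higher number from compound 2 to compound 3 (0.58 log units; beyond the scatter) and both are modest. In each, the compound with 2-ethylphenyl has the higher number, so removing that group may bring a modest move to a lower number, though this is indirect evidence. The expected change is a 2.4-fold lower number from compound 3 to compound 4 (0.38 log units; beyond the scatter) and it remains an estimate.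

Compound 4 is expected to give about 10000 nM in this assay, with an estimated range from 3500 nM to 28000 nM in this measurement.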

Compound 4, half-maximal inhibitory concentration: 3760 nM
Beside the measured number, compound 4's estimate is 2.7-fold (0.42 log units) above it; low and high end bracket the measured number.
By their numbers in this assay, from the lowest: compounds 4, 2 and 1 (each within the scatter of the next, the first and the last beyond it); then compound 3.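

In this assay the carbonyl carbon now shows its largest step among these compounds, a 6.4-fold lower number from compound 3 to compound 4 (0.80 log units; beyond the scatter) for quinolin-2-yl in place of 2-ethylphenyl, and the entering group is the first here with a six-membered aromatic ring holding a hetero atom and with a hydrogen-bond acceptor. The same group is set apart from 4-methylphenyl, with a 3.0-fold lower number from compound 1 to compound 4 (0.48 log units; beyond the scatter) but not from 4-bromophenyl, with a 1.7-fold lower number from compound 2 to compound 4 (0.22 log units; within the scatter) and so it does not stand apart from every earlier group at this place. No measurement is available that would tie these steps to any property of the groups.

The compounds shown leave open whether the ring nitrogen of quinolin-2-yl or its second ring goes with the lower number, as neither pyridin-2-yl nor naphthalen-2-yl stands among them on this carbonyl carbon. Also open, from the compounds shown here alone, is how an amine or a carboxylic acid on the quinolin-2-yl group would read in this assay and whether the step would hold on any core other than the shared one.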